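Shifting Fluorine on the Benzyl Arm of a Weak Series

The source may report more compounds than this note shows. Statements on the series, on what has been measured and on what is new or still open speak of the compounds shown alone.

Compound 1 `CCOC(=O)CN(Cc1cc(F)cc(F)c1)c1ccc2c(c1)OC(C)(COc1ccc(C#N)cc1)CN2C` is one of three compounds examined in a functional assay on HMEC-1 cells (Homo sapiens) for antiproliferative activity, read by cell counting, with a stated time of 7 days (a lower number here means a stronger inhibitor, a higher number a weaker inhibitor), where compound 1 gives 49000 nM. Compound 2 `CCOC(=O)C(=O)N(Cc1cc(F)cc(F)c1)c1ccc2c(c1)OC(C)(CO)CN2C` gives 89000 nM in this assay, and the gap between the two lies within the usual scatter, so compound 1 stands level with compound 2 rather than apart from it. Compound 3 `CCOC(=O)CN(Cc1cccc(F)c1)c1ccc2c(c1)N(C)CC(C)(COc1ccc(C#N)cc1)O2` gives only > 100000 nM, which is a limit of this assay and not a number, the case at the limit of > 100000 nM in this assay, at which 1 of the 3 values shown sits. Compound 4 `CCOC(=O)CN(Cc1ccc(F)cc1)c1ccc2c(c1)OC(C)(COc1ccc(C#N)cc1)CN2C` has not yet been measured in this assay. It differs from compound 1 in one place: 4-fluorophenyl in place of 3,5-difluorophenyl on a saturated chain carbon bound to a nitrogen on an aromatic ring. Among the measured compounds shown here, no measured pair here shows a step of this kind, so its size is open. Since compound 1 gives 49000 nM and all three known results sit at weak inhibition, the change is expected to move the number little, or toward a weaker inhibitor, at most slightly beyond the scatter. Compound 4 is therefore estimated at 75000 nM, between 30000 nM and 200000 nM. That estimate means a step of a 1.5-fold higher number from compound 1 to compound 4 (0.18 log units; within the scatter).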

Compound 4, half-maximal inhibitory concentration: > 100000 nM
Compound 4: only a limit was reported; the forecaster's own chance of this, stated with the estimate: 40%; middle value at least 1.3-fold (0.12 log units) away from the limit.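

In this assay compound 4 gives > 100000 nM, which is a limit of the assay and not a number. The change to 4-fluorophenyl in place of 3,5-difluorophenyl on a saturated chain carbon bound to a nitrogen on an aromatic ring gives the first step readable at this position, an at least 2.0-fold higher number from compound 1 to compound 4 (0.30 log units; that floor lies within the scatter), so it shows no loss that clearly exceeds the scatter. The change also adds a second compound at the limit and gives no number for the 4-fluorobenzyl arm: the limit of > 100000 nM in this assay, at which 2 of the 4 values shown sit.

Going by these compounds, how far the true value of compound 4 lies past the limit stays open, and so does whether the count of fluorines or their place on the ring matters. On these data alone, it is also open whether an unsubstituted benzyl or a benzyl carrying an amine would give a readable number in this place.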